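Chloro for fluoro on the shared core

The compounds below may be only part of what the source reports. "The series", "measured", "known", "first", "only" and "open" are said of these compounds alone.

In a functional assay on NCI-H460 cells (Homo sapiens) for antiproliferative activity, read by sulforhodamine B assay, with a stated time of 48 h (a lower number here means a stronger inhibitor, a higher number a weaker inhibitor), compound 1 (`O=C(CCCCCCN1C(=O)/C(=N\O)c2ccccc21)NO`) gives 890 nM and compound 2 (`O=C(CCCCCCN1C(=O)/C(=N\O)c2cc(F)ccc21)NO`) gives 1500 nM as its half-maximal inhibitory concentration. Compound 2 thus stands within the scatter of compound 1, and the two cannot be ranked on these numbers. The next compound, compound 3 (`O=C(CCCCCCN1C(=O)/C(=N\O)c2cc(Cl)ccc21)NO`), departs from compound 2 in one place only. The change is chloro in place of fluoro on an aromatic carbon and the rest of the structure stays the same. Within the data shown here, one measured step bears on it: fluoro in place of hydrogen on that same aromatic carbon gave a 1.7-fold higher number from compound 1 to compound 2 (0.23 log units; within the scatter) and so stayed within the scatter. Among the measured compounds shown here, no chloro compound has a measured value yet, so this single step is thin support. On that basis no step beyond the scatter is expected in this assay, and no direction can be argued with confidence. The estimated step is a 1.3-fold lower number from compound 2 to compound 3 (0.10 log units; within the scatter) and it is expected to remain within the scatter. For compound 3 the expected value is 1200 nM with an estimated range from 500 nM to 3000 nM in this measurement.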

Compound 3, half-maximal inhibitory concentration: 850 nM
The estimate for compound 3 lay 1.4-fold (0.15 log units) above the measured number; the range from low to high includes it.
By their numbers in this assay, from the lowest: compounds 3, 1 and 2 (each within the scatter of the next).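

In this assay, the step from fluoro to chloro is a 1.8-fold lower number from compound 2 to compound 3 (0.25 log units; within the scatter), and the step from hydrogen to chloro on the same aromatic carbon is a 1.0-fold lower number from compound 1 to compound 3 (0.02 log units; within the scatter). Before this result, only fluoro had been compared with hydrogen at this position; now hydrogen, fluoro and chloro have all been read there, and none of the three compounds can be separated from the others, so neither halogen gives a step beyond the scatter at this carbon, which is meta to a fused ring and para to a fused ring. Nothing available accounts for why the three numbers lie so close together.

The compounds shown leave open whether a bromo, methoxy, nitro or amino group on this aromatic carbon would give a step beyond the scatter, or whether the two halogens would behave the same way on another carbon of that ring. They also leave open how a shorter or longer chain on the shared core would compare with the chain common to compound 1, compound 2 and compound 3.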